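This account rests on a few compounds, and the source may have more. Where it says the series, first, only, none or still open, it means among the compounds named here.

Among the measured compounds shown here, in an ADME assay for permeability, using PAMPA, with a stated time of 4 h, at pH 5.5 (on this read-out lower numbers stand for lower permeability and higher numbers for higher permeability), compound 1 `CN(C[C@H]1Cc2ncccc2CN1)[C@H]1CCCc2cccnc21` gives 460 nm/s, the highest number of the three measured so far. Compound 2 `NC/C=C/CN(C[C@H]1Cc2ncccc2CN1)[C@H]1CCCc2cccnc21` gives 2 nm/s, and compound 3 `NC(=O)NC/C=C\CN(C[C@H]1Cc2ncccc2CN1)[C@H]1CCCc2cccnc21` gives 5 nm/s, so compound 3 stands second highest and far nearer the low end of the numbers.

Compound 4 `CN(C)CCCCN(C[C@H]1Cc2ncccc2CN1)[C@H]1CCCc2cccnc21` is not yet measured. It differs from compound 3 at one place: a group of 6 heavy atoms (5 carbon, 1 nitrogen; no ring) in place of a group of 7 heavy atoms (4 carbon, 2 nitrogen, 1 oxygen; no ring), on a saturated chain carbon bound to an amine nitrogen. The group that enters is 3-(dimethylamino)propyl, on a saturated chain carbon bound to an amine nitrogen.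

All three measured steps bear on this change. Adding a chain gave a 230-fold lower number from compound 1 to compound 2 (2.36 log units; beyond the scatter) and a 92-fold lower number from compound 1 to compound 3 (1.96 log units; beyond the scatter), both large. Exchanging one chain for another gave only a 2.5-fold higher number from compound 2 to compound 3 (0.40 log units; beyond the scatter), a modest step. For the measured compounds named here, compound 4 also carries a chain at this place, so that modest step is the closer guide, although it is the only chain-for-chain exchange available. Going by the values given here, no measured compound carries the entering group, which leaves the direction open.

The expected result is no change beyond the scatter in this assay, with a 1.2-fold higher number from compound 3 to compound 4 (0.08 log units; within the scatter) as the estimated step. For compound 4 the estimated value is 6 nm/s, with an expected range from 1.5 nm/s to 25 nm/s.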

Compound 4, apparent permeability: 2 nm/s
Estimate against measurement, compound 4: 3.0-fold (0.48 log units) above; measured number inside the range.
By their numbers in this assay, from the lowest: compounds 2 and 4 (each within the scatter of the next); then compound 3; then compound 1.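

In this assay, 3-(dimethylamino)propyl in place of hydrogen on this saturated chain carbon gives a 230-fold lower number from compound 1 to compound 4 (2.36 log units; beyond the scatter) as the step, so a large step at this place now also appears with a chain that has no double bond and no hydrogen-bond donors. The exchange of 3-aminoprop-1-en-1-yl for 3-(dimethylamino)propyl gives no change at the digits printed from compound 2 to compound 4 (within the scatter) as its step, which shows two differently substituted amine chains printing alike in this read-out. Among the compounds shown here, the exchange of the chain of compound 3 for 3-(dimethylamino)propyl gives a 2.5-fold lower number from compound 3 to compound 4 (0.40 log units; beyond the scatter) as its step, so among the three chains only the one in compound 3 stands apart from the others, and only by a modest step. No measurement on hand speaks to what lies behind these steps.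

The compounds shown leave open whether any group at this place gives numbers this low, or whether a small ethyl group or a chain ending in a carboxylic acid would land nearer compound 1. Compounds 2 and 4 differ both in the double bond and at the amine end, and a saturated 3-aminopropyl chain would separate those two changes.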